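Morpholine for piperidine on the dithiocarbamate of compound 1

This account rests on a few compounds, and the source may have more. Where it says the series, first, only, none or still open, it means among the compounds named here.

Measured compounds:
compound 1, `O=c1cc(CSC(=S)N2CCCCC2)oc2cc(Cl)ccc12`, 13800 nM
compound 2, `COc1ccc2occ(CSC(=S)N3CCOCC3)c(=O)c2c1`, > 40000 nM

Going by the values given here, in a functional assay on LM7 cells (Homo sapiens) for antiproliferative activity, read by MTT assay, with a stated time of 72 h (on this read-out lower numbers stand for stronger inhibition and higher numbers for weaker inhibition), compound 1 gives 13800 nM, the only numerical value in the set. Compound 2 gives > 40000 nM in this assay, which is a limit of the assay and not a number; this is noted as the limit of > 40000 nM in this assay, at which 1 of the 2 values shown sits.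

The unmeasured compound 3, `O=c1cc(CSC(=S)N2CCOCC2)oc2cc(Cl)ccc12`, keeps the core of compound 1 and differs from it only in one place: morpholin-4-yl in place of piperidin-1-yl on a thiocarbonyl carbon. Among the compounds with values here, no step between measured compounds shares this change, so there is no measured step to lean on; of compound 2 and compound 3, which both carry the morpholin-4-yl, only the limit of compound 2 is known, on a different core.

For compound 3 a small step in this assay is expected, towards weaker inhibition, with the estimated step from compound 1 to compound 3 being a 1.8-fold higher number from compound 1 to compound 3 (0.26 log units; within the scatter), and a fair chance that only a limit is reported. The estimate for compound 3 in this assay is 25000 nM, with a range from 9000 nM to 60000 nM.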

Compound 3, half-maximal inhibitory concentration: > 25000 nM
Compound 3: a limit, no number; the forecaster's own chance of this, stated with the estimate: 35%; the middle value lies on the limit itself.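

In this assay, compound 3 is reported only as a limit of the assay and not as a number: the limit of > 25000 nM in this assay, at which 1 of the 3 values shown sits.

Going by these compounds alone, on the core of compound 1, morpholin-4-yl in place of piperidin-1-yl on a thiocarbonyl carbon gives the only step between compounds that differ in one place, an at least 1.8-fold higher number from compound 1 to compound 3 (0.25 log units; that floor lies within the scatter). Both morpholin-4-yl compounds shown, compound 2 and compound 3, now stand as limits on different cores, while the only number in the set stays with the piperidin-1-yl compound 1.

From the compounds shown here alone, how far compound 3 really lies from compound 1 stays open, and a floor inside the scatter cannot say whether this change matters at all in this assay. Also open, going by these compounds, is whether another amine on the thiocarbonyl carbon, such as 4-methylpiperazin-1-yl or an open-chain diethylamino group, would give a number on this core that could be set against that of compound 1, which stands at 13800 nM.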